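This account rests on a few compounds, and the source may have more. Where it says the series, first, only, none or still open, it means among the compounds named here.

Measured in a functional assay on MV4-11 cells (Homo sapiens) for antiproliferative activity; on this read-out higher numbers stand for weaker inhibition and lower numbers for stronger inhibition:
- compound 1 `NC(=O)c1c(NC(=O)C2CC2)sc2c1CCCC2`: 1200 nM
- compound 2 `Cc1ccc(C(=O)Nc2sc3c(c2C(N)=O)CCCC3)cc1`: 450 nM
- compound 3 `COc1ccc(C(=O)Nc2sc3c(c2C(N)=O)CCCC3)cc1`: 1300 nM

In this assay compound 3 gives 1300 nM, which lies within the scatter of compound 1 at 1200 nM. Only compound 2 stands clearly apart from it, as a 2.9-fold higher number from compound 2 to compound 3 (0.46 log units; beyond the scatter) shows.

The next structure, compound 4 `CC(=O)c1ccc(C(=O)Nc2sc3c(c2C(N)=O)CCCC3)cc1`, has acetyl in place of methoxy on an aromatic carbon. The rest of the molecule stays the same.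

One measured step changes this same place: a 2.9-fold higher number from compound 2 to compound 3 (0.46 log units; beyond the scatter), which is modest, with methoxy in place of methyl. The other, a 2.7-fold lower number from compound 1 to compound 2 (0.43 log units; beyond the scatter), swaps the whole group on a carbonyl carbon and is also modest. Together they suggest that changes of this kind have moved the number only modestly so far. Among the measured compounds shown here, no measured compound carries acetyl, so the direction is uncertain. A small move towards the lower numbers is expected, perhaps none beyond the scatter, and a step larger than those already seen is not expected.

The estimate therefore means a 1.6-fold lower number from compound 3 to compound 4 (0.21 log units; within the scatter), an expected rather than a measured step.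

For compound 4 the expected value is 800 nM, with an estimated range from 300 nM to 2200 nM.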

Compound 4, half-maximal inhibitory concentration: 1800 nM
The estimate for compound 4 lay 2.3-fold (0.35 log units) below the measured number, and the stated range covers the measured number.
By their numbers in this assay, from the lowest: compound 2; then compounds 1, 3 and 4 (each within the scatter of the next).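

In this assay, putting acetyl in place of methoxy on this aromatic carbon, para to a large group, gives a 1.4-fold higher number from compound 3 to compound 4 (0.14 log units; within the scatter), so this assay does not separate these two groups, even though acetyl brings a double bond outside the aromatic ring. Among the compounds shown here, measured against the methyl group, acetyl gives a 4.0-fold higher number from compound 2 to compound 4 (0.60 log units; beyond the scatter), the largest step yet at this place; together with a 2.9-fold higher number from compound 2 to compound 3 (0.46 log units; beyond the scatter), this leaves methyl as the only one of the three groups clearly apart from the others, with none of the three going against that picture. Nothing measured here explains why methyl stands apart from the two oxygen-bearing groups.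

The compounds shown leave open whether the lower number belongs to methyl alone or would also appear with a small group such as ethyl or chlorine, or with plain hydrogen, and how an amine or a carboxylic acid on the same carbon would read in this assay. They also leave open whether methyl, methoxy and acetyl would keep this order on a different carbon of the same aromatic ring.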